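The source may report more compounds than this note shows. Statements on the series, on what has been measured and on what is new or still open speak of the compounds shown alone.

Compound 1 `CC1=C(C(=O)OC2CCCC2)C(c2ccco2)NC(=O)N1` gives 14% in an assay on membranes from HeLa cells for displacement of a labelled ligand from adenosine receptor A3 (Homo sapiens), read by scintillation counting, with a stated time of 180 min, tested at 1 uM; on this read-out higher numbers stand for more inhibition at the one concentration tested (going by the name of the read-out) and lower numbers for less inhibition. Compound 2 `CC1=C(C(=O)OC2CCCCC2)C(c2ccco2)NC(=O)N1` carries the change cyclohexyl in place of cyclopentyl on an oxygen next to a carbonyl group and gives 4%, so that the step of a number 10 percentage points lower from compound 1 to compound 2 (within the scatter) stays within the scatter of this assay. Compound 3 `CC1=C(C(=O)OC2CCCC2)C(c2ccoc2)NC(=O)N1` differs from compound 1 in its core by furan-3-yl in place of furan-2-yl on a saturated ring carbon, and in this assay compound 3 gives 1%, a step of a number 13 percentage points lower from compound 1 to compound 3 (beyond the scatter). Compound 4 `CC1=C(C(=O)OC2CCCCC2)C(c2ccoc2)NC(=O)N1` has not been measured; it differs from compound 3 by cyclohexyl in place of cyclopentyl on an oxygen next to a carbonyl group, which is the same change as that from compound 1 to compound 2, made at the same place. Since that earlier step lay within the scatter and compound 3 already sits at 1%, the step to compound 4 is expected to be small, no change at the digits printed from compound 3 to compound 4 (within the scatter). Compound 4 is therefore estimated to give 1%, between -6% and 9%.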

Compound 4, a percentage reported as inhibition, at one concentration (the size of the read-out at that concentration, not a potency): 1%
Estimate against measurement, compound 4: no gap at the digits printed; the range from low to high includes it.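

In this assay, cyclohexyl in place of cyclopentyl gives no change at the digits printed from compound 3 to compound 4 (within the scatter), which sits close to the earlier step for that change: the same change on two cores in this assay, a number 10 percentage points lower (within the scatter) from compound 1 to compound 2 and no change at the digits printed (within the scatter) from compound 3 to compound 4, 10 percentage points apart, within the scatter of two such steps. Furan-3-yl in place of furan-2-yl gives a number 3 percentage points lower from compound 2 to compound 4 (within the scatter), and here too the earlier step stands close: the same change on two cores in this assay, a number 13 percentage points lower (beyond the scatter) from compound 1 to compound 3 and a number 3 percentage points lower (within the scatter) from compound 2 to compound 4, 10 percentage points apart, within the scatter of two such steps. Both changes thus carry between these cores with no difference beyond the scatter, but with so little inhibition at the one concentration tested, this does not show that either step would hold on a core giving much higher numbers. The compounds shown leave open what a longer chain or an amine on that oxygen would give. They also leave open what a thiophene in place of the furan would give.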